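Ring Size Change at the Amine of Two Thiazole Cores

This account rests on a few compounds, and the source may have more. Where it says the series, first, only, none or still open, it means among the compounds named here.

The study compares two pairs of compounds that share one structural change. Compound 1 `O=C(c1ccccc1)c1sc(N2CCCC2)nc1Cl` and compound 2 `O=C(c1ccccc1)c1sc(N2CCCCC2)nc1Cl` differ only in piperidin-1-yl in place of pyrrolidin-1-yl on an aromatic carbon. In a functional assay on Hs 683 cells (Homo sapiens) for cytotoxicity, read by MTT assay, with a stated time of 72 h (a higher number here means a weaker inhibitor, a lower number a stronger inhibitor), compound 1 gives 44000 nM, and compound 2 gives 36000 nM, so that a 1.2-fold lower number from compound 1 to compound 2 (0.09 log units; within the scatter).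

Compound 3 `COC(=O)c1sc2nc(N3CCCC3)sc2c1C` is built on a different core; how its core differs from that of compound 1 is not broken down here. In this assay compound 3 gives 91000 nM, the highest number of the three, and its gaps to compound 1 and to compound 2 both lie beyond the scatter. Compound 4 `COC(=O)c1sc2nc(N3CCCCC3)sc2c1C` differs from compound 3 in piperidin-1-yl in place of pyrrolidin-1-yl on an aromatic carbon. This is the same kind of change as that from compound 1 to compound 2, but its surroundings differ: here the aromatic carbon is part of a fused or bridged system of two rings, whereas in compound 1 it lies two ring bonds from the ring atom that bears a chloro group and two ring bonds from the ring atom that bears a group of 8 heavy atoms.

For compound 4 the step is expected to be small, a 1.1-fold lower number from compound 3 to compound 4 (0.06 log units; within the scatter), because the same kind of change gave a 1.2-fold lower number from compound 1 to compound 2 (0.09 log units; within the scatter). Compound 4 is therefore estimated at 80000 nM in this assay, in a range from 40000 nM to 160000 nM.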

Compound 4, half-maximal inhibitory concentration: > 100000 nM
Compound 4: a limit, no number; the forecaster's own chance of this, stated with the estimate: 15%; at least 1.2-fold (0.09 log units) between middle value and limit.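

In this assay compound 4 gives > 100000 nM, which is a limit of the assay and not a number. Going by these compounds, the step on this core can therefore be read only as a floor, an at least 1.0-fold higher number from compound 3 to compound 4 (0.04 log units; that floor lies within the scatter), and its true size stays unknown. The result neither confirms nor rules out that piperidin-1-yl in place of pyrrolidin-1-yl acts alike on both cores, so it offers no firm support for carrying this change from one core to the other: the same change on two cores in this assay, a 1.2-fold lower number (0.09 log units; within the scatter) from compound 1 to compound 2 and an at least 1.0-fold higher number (0.04 log units; that floor lies within the scatter) from compound 3 to compound 4; the limit leaves it open whether they differ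

The compounds shown leave open how other amines, such as morpholin-4-yl or an open-chain dimethylamino group, would read at this aromatic carbon on either core. They also leave open whether a carboxylic acid or an amide in place of the methyl ester on the core of compound 3 would shift its number in this assay, and whether the ring size of the amine would then matter.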